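Replacing the Acetyl-Pyrazole of Compound 3 with Pyridine

The source may hold more compounds than are shown below. What is called first, only, known or untested is meant among the compounds shown, and "the series" means these compounds.

Of the compounds shown here, three sharing one core have been tested in a functional assay on MV4-11 cells (Homo sapiens) for antiproliferative activity, with a stated time of 6 days, tested at 6.25 uM; a higher number here means a stronger effect of the compound at the concentration tested, a lower number a weaker effect. Compound 1 `CNC(=O)N1CCCc2ccc(NC(=O)c3ccc(-c4cc[nH]n4)cc3)cc21` carries a 1H-pyrazol-3-yl ring on an aromatic carbon and gives 99.1%. Compound 2 `CNC(=O)N1CCCc2ccc(NC(=O)c3ccc(-c4ccccc4)cc3)cc21` carries a phenyl ring on that aromatic carbon and gives 74.3%. Compound 3 `CNC(=O)N1CCCc2ccc(NC(=O)c3ccc(-c4ccn(C(C)=O)n4)cc3)cc21` carries a 1-acetyl-1H-pyrazol-3-yl ring there and gives 91.4%. Among these three numbers compound 3 stands second highest: its gap to compound 1 lies within the scatter, while it sits clearly above compound 2.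

Compound 4 `CNC(=O)N1CCCc2ccc(NC(=O)c3ccc(-c4ccncc4)cc3)cc21` has not yet been measured. Compared with compound 3 the change is pyridin-4-yl in place of 1-acetyl-1H-pyrazol-3-yl on an aromatic carbon. Among the compounds with values here, two measured steps bear on this kind of swap. Exchanging the pyrazole for a plain phenyl cost a number 24.8 percentage points lower from compound 1 to compound 2 (beyond the scatter), and putting the acetyl-pyrazole in place of the phenyl brought back a number 17.1 percentage points higher from compound 2 to compound 3 (beyond the scatter); the acetyl on an aromatic nitrogen by itself changed little, a number 7.7 percentage points lower from compound 1 to compound 3 (within the scatter). A pyridine ring keeps one hydrogen-bond acceptor that phenyl lacks but has fewer than the acetyl-pyrazole, so a modest fall in this assay, near the edge of the scatter, is expected: a number 7.4 percentage points lower from compound 3 to compound 4 (within the scatter). Compound 4 is therefore estimated at 84%, within 70% to 96%.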

Compound 4, a percentage reported as inhibition, at one concentration (the size of the read-out at that concentration, not a potency): 88.7%
Beside the measured number, compound 4's estimate is 4.7 percentage points below it; measured number inside the range.
By their numbers in this assay, from the lowest: compound 2; then compounds 4, 3 and 1 (each within the scatter of the next, the first and the last beyond it).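

In this assay, the step to pyridin-4-yl gives a number 2.7 percentage points lower from compound 3 to compound 4 (within the scatter), and the same swap made on the plain phenyl gives a number 14.4 percentage points higher from compound 2 to compound 4 (beyond the scatter). The advantage over phenyl at this aromatic carbon had so far been seen only with five-membered aromatic rings holding 2 hetero atoms, and it now also appears with a six-membered aromatic ring holding 1 hetero atom, so all three nitrogen-containing rings shown stand beyond the scatter of phenyl, with no exception among these compounds. The ring type still leaves a visible difference, since the unsubstituted pyrazole keeps its edge in a number 10.4 percentage points lower from compound 1 to compound 4 (beyond the scatter), and nothing available here explains why these rings differ.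

Open, as far as these compounds go, is whether the placing of the ring nitrogen matters, which pyridin-3-yl and pyridin-2-yl would test, and whether an amino group or a carboxylic acid on the pyridine ring would shift the read-out. Each number is also a read-out at one concentration, so it shows only the size of the effect at that concentration, and how the effects of compounds 1, 3 and 4 compare at other concentrations stays unsettled.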